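Methoxy in place of hydrogen: compound 2 to compound 3

This account rests on a few compounds, and the source may have more. Where it says the series, first, only, none or still open, it means among the compounds named here.

Measured so far in an ADME assay on BHK-21 cells (Mesocricetus auratus) for cytotoxicity, read by MTT assay (a higher number here means that more compound is tolerated, a lower number that less compound is tolerated), for two compounds
- compound 1 `COc1ccc(-c2nc3cc(C(C)=O)ccc3[nH]2)c(OC)c1` gives 50000 nM
- compound 2 `COc1ccc(-c2nc3cc(C(C)O)ccc3[nH]2)cc1` gives > 100000 nM

Compound 2 stands at > 100000 nM in this assay, which is a limit of the assay and not a number. Compound 3 `COc1ccc(-c2nc3cc(C(C)O)ccc3[nH]2)c(OC)c1` carries methoxy in place of hydrogen on an aromatic carbon, ortho to a large group and meta to a methoxy group (methoxy in place of hydrogen on an aromatic carbon). Among the measured compounds shown here, no measured step shows what this exchange does in this assay. A small step toward less compound tolerated is expected, little beyond the scatter. For the measured compounds named here, the expectation leans on compound 1 at 50000 nM, the only number. The expected change is an at least 1.2-fold lower number from compound 2 to compound 3 (0.09 log units; that floor lies within the scatter), and the assay may again report only a limit. For compound 3 the estimate is 80000 nM, with an expected range of 35000 nM to 180000 nM in this assay.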

Compound 3, half-maximal cytotoxic concentration: > 100000 nM
Compound 3 was reported as a limit; the forecaster's own chance of this, stated with the estimate: 45%; middle value at least 1.2-fold (0.09 log units) from the limit.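

In this assay the first readable step of the series comes from 1-hydroxyethyl in place of acetyl on an aromatic carbon, which gives an at least 2.0-fold higher number from compound 1 to compound 3 (0.30 log units; that floor lies within the scatter) and so is not shown to exceed the scatter. Compound 3 at > 100000 nM is a limit of the assay and not a number. The step for methoxy in place of hydrogen, ortho to a large group, cannot be read, because both of its ends are limits: the limit of > 100000 nM in this assay, at which 2 of the 3 values shown sit.

Open, as far as these compounds go, is whether methoxy in place of hydrogen at this position changes the tolerated concentration at all, which would need a pair with a number at both ends, such as an acetyl compound lacking this methoxy. Also open, from the compounds shown here alone, is whether an amine or a carboxylic acid in place of 1-hydroxyethyl would give a number rather than a limit.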